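Two Inactive Amides and a Methoxy Swap

This account rests on a few compounds, and the source may have more. Where it says the series, first, only, none or still open, it means among the compounds named here.

Compound 1 `C=CC1=C(C(=O)NC2CCCCC2)C(c2ccc(OC)cc2)OC1` and compound 2 `C=CC1=C(C(=O)NCCCCC)C(c2ccc(F)cc2)OC1` share a core that carries a vinyl group, an amide and an aryl ring. In a functional assay on SW480 cells (Homo sapiens) for cytotoxicity, read by MTT assay, with a stated time of 24 h (a lower number here means a stronger inhibitor, a higher number a weaker inhibitor), compound 1 reaches only the limit of > 100000 nM, which is a limit and not a number. In this assay compound 2 likewise stops at > 100000 nM, again a limit rather than a measured number. Compound 2 therefore stands at the limit of > 100000 nM in this assay, at which 2 of the 2 values shown sit, with no measurable potency to compare. Compound 3 `C=CC1=C(C(=O)NCCCCC)C(c2ccc(OC)cc2)OC1` differs from compound 2 by methoxy in place of fluoro on an aromatic carbon. Since compound 1, which already carries this methoxy, sits at > 100000 nM, no step beyond the scatter is expected from compound 2 to compound 3, and a step that the limit leaves unreadable from compound 2 to compound 3 is the expected change. Compound 3 is expected to give about 150000 nM, between 50000 nM and 500000 nM, most likely reported again as a limit.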

Compound 3, half-maximal inhibitory concentration: > 100000 nM
Compound 3 gave a limit, no number; the forecaster's own chance of this, stated with the estimate: 85%; the middle value does not contradict the limit.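

Compound 3 ends at a limit and not a number, as do compound 1 and compound 2, so neither step to compound 3 can be read in this assay: the limit of > 100000 nM in this assay, at which 3 of the 3 values shown sit.

The compounds shown leave open whether any other amide or aryl group on the shared core would give a measured number in this assay.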